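Methyl on the Pyrrole Nitrogen in the Triazolothiadiazine Series

The source may hold more compounds than are shown below. What is called first, only, known or untested is meant among the compounds shown, and "the series" means these compounds.

Compound 1 `COc1ccc(Cl)c(-c2nnc3n2NC(c2ccc([N+](=O)[O-])o2)S3)c1` gives 18.5% in a functional assay on the whole organism (strain Wistar Albino) for inhibition, with Rattus norvegicus as the target, read by paw edema, with a stated time of 2 h, at a dose of 20 mg/kg; a lower number here means less inhibition, a higher number more inhibition at the dose given (going by the name of the read-out). Compound 2 `COc1ccc(Cl)c(-c2nnc3n2NC(c2ccc[nH]2)S3)c1` gives 15.2% there, the lower of the two numbers, with the step of a number 3.3 percentage points lower from compound 1 to compound 2 (within the scatter) lying within the scatter. Compound 3 `COc1ccc(Cl)c(-c2nnc3n2NC(c2cccn2C)S3)c1` differs from compound 2 by methyl in place of hydrogen on an aromatic nitrogen. Among the measured compounds shown here, the only measured step, the exchange of the whole group on the saturated ring carbon, moved the inhibition little, and a single methyl on the aromatic nitrogen is a smaller change; no step beyond the scatter is expected. Compound 3 is estimated at 16%, between 8% and 26%, a step of a number 0.8 percentage points higher from compound 2 to compound 3 (within the scatter).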

Compound 3, a percentage reported as inhibition, in the whole organism at one dose (the size of the read-out at that dose, not a potency): 16.8%
Compound 3: the middle estimate sits 0.8 percentage points below what was measured; the measured number falls inside the stated range.
By their numbers in this assay, from the lowest: compounds 2, 3 and 1 (each within the scatter of the next).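

In this assay, the exchange of hydrogen for methyl on the aromatic nitrogen gives a number 1.6 percentage points higher from compound 2 to compound 3 (within the scatter), so this position does not separate the two groups at this dose. Against 5-nitrofuran-2-yl on the saturated ring carbon, 1-methyl-1H-pyrrol-2-yl gives a number 1.7 percentage points lower from compound 1 to compound 3 (within the scatter), so these two groups are not separated either. Nothing available bears on why these numbers lie so close. As far as these compounds go, whether a longer chain or a carboxylic acid on this nitrogen would give a step beyond the scatter remains open. So does the effect of an amine on the saturated ring carbon.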